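The source may hold more compounds than are shown below. What is called first, only, known or untested is meant among the compounds shown, and "the series" means these compounds.

Measured in a functional assay on A549 cells (Homo sapiens) for inhibition, read by MTT assay, with a stated time of 72 h; a higher number here means a weaker inhibitor, a lower number a stronger inhibitor:
- compound 1 `O=C1/C(=C\c2ccccc2)c2c(ncn2COCc2ccccc2)CCN1Cc1ccc(F)cc1`: 19600 nM
- compound 2 `O=C1/C(=C\c2ccccc2)c2c(ncn2COCc2ccccc2)CCN1Cc1ccc(-c2ccccc2)cc1`: 18300 nM
- compound 3 `COc1ccc(CN2CCc3ncn(COCc4ccccc4)c3/C(=C/c3ccccc3)C2=O)cc1`: 46800 nM

Compound 3 has the highest number of the three, which makes it the weakest inhibitor in this small set. The next compound, compound 4 `O=C1/C(=C\c2ccccc2)c2c(ncn2COCc2ccccc2)CCN1Cc1ccc2ccccc2c1`, keeps the shared core and changes one group: naphthalen-2-yl in place of 4-methoxyphenyl on a saturated chain carbon bound to an amide-type nitrogen in a ring.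

Among the compounds with values here, no compound with naphthalen-2-yl has been measured yet, so the nearest evidence comes from changes on the same outer aromatic ring. Replacing the fluoro of compound 1 with methoxy gave a 2.4-fold higher number from compound 1 to compound 3 (0.38 log units; beyond the scatter). Replacing the phenyl of compound 2 with methoxy gave a 2.6-fold higher number from compound 2 to compound 3 (0.41 log units; beyond the scatter). Fluoro and phenyl themselves hardly differ, with a 1.1-fold lower number from compound 1 to compound 2 (0.03 log units; within the scatter). Compound 4 also lacks the methoxy, so it is expected to land close to compound 1 and compound 2 in this assay, though three compounds make a thin basis for this. The expected change is modest and towards stronger inhibition, namely a 2.3-fold lower number from compound 3 to compound 4 (0.37 log units; beyond the scatter). For compound 4 the estimated value is 20000 nM, with an expected range of 9000 nM to 42000 nM.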

Compound 4, half-maximal inhibitory concentration: 26400 nM
For compound 4 the middle estimate is 1.3-fold (0.12 log units) below the measured one; measured number inside the range.
By their numbers in this assay, from the lowest: compounds 2, 1, 4 and 3 (each within the scatter of the next, the first and the last beyond it).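

In this assay, the saturated chain carbon bound to an amide-type nitrogen in a ring now carries naphthalen-2-yl, with its two six-membered aromatic rings of carbon only: in place of 4-methoxyphenyl it gives a 1.8-fold lower number from compound 3 to compound 4 (0.25 log units; within the scatter), in place of 4-phenylphenyl it gives a 1.4-fold higher number from compound 2 to compound 4 (0.16 log units; within the scatter), and in place of 4-fluorophenyl it gives a 1.3-fold higher number from compound 1 to compound 4 (0.13 log units; within the scatter). Compound 4 therefore cannot be told apart from any of the three earlier compounds, even though compound 3 stands apart from both compound 1 and compound 2, so this result does not add a further clear separation among the groups at this position. No measurement shown here offers an explanation for this result.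

Still open is how an amine or a carboxylic acid on the outer aromatic ring would read in this assay, as all four groups shown are built on aromatic rings of carbon. Also open, from the compounds shown here alone, is whether a longer chain between the amide-type nitrogen and that ring would shift the number beyond the scatter, in either direction.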